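A few compounds are considered here, and "the series" means these few. Any claim that something is new, unique, unknown or untested is made for them only; others in the source may bear on it.

Of the compounds shown here, three sharing one core have been measured. Compound 1 `Cc1c(Br)sc(N)c1C(=O)c1ccc(Cl)cc1` gives in an assay on CHO cells for displacement of a labelled ligand from adenosine receptor A3 (Homo sapiens), read by scintillation counting, tested at 10 uM (a higher number here means more inhibition at the concentration tested (going by the name of the read-out), a lower number less inhibition), 1%. Compound 2 `CC(C)(C)Cc1csc(N)c1C(=O)c1cccc(Cl)c1` gives in this assay 8%, and compound 3 `CC(C)(C)Cc1c(-c2ccncc2)sc(N)c1C(=O)c1ccc(Cl)cc1` gives in this assay 6%. Compound 3 thus lies within the usual scatter of both compound 2 and compound 1, so nothing separates the three numbers. Compound 4 `CC(C)(C)Cc1c(-c2c(F)cccc2F)sc(N)c1C(=O)c1ccc(Cl)cc1` differs from compound 3 in one place: 2,6-difluorophenyl in place of pyridin-4-yl on an aromatic carbon. Among the compounds with values here, no measured pair shows what such an exchange does in this assay. Compound 3 shows 6%, and the two other compounds sit in the same low region. The expected step of no change at the digits printed from compound 3 to compound 4 (within the scatter) is therefore none beyond the scatter. Compound 4 is estimated at 6% in this assay, with a range from 0% to 20%.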

Compound 4, a percentage reported as inhibition, at one concentration (the size of the read-out at that concentration, not a potency): 1%
The estimate for compound 4 lay 5 percentage points above the measured number; the measured number falls inside the stated range.
By their numbers in this assay, from the lowest: compounds 1, 4, 3 and 2 (each within the scatter of the next).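

Exchanging pyridin-4-yl for 2,6-difluorophenyl on the aromatic carbon next to the ring sulfur gives a number 5 percentage points lower from compound 3 to compound 4 (within the scatter) in this assay. At this position, then, an all-carbon ring with no hydrogen-bond acceptor in place of a ring with one hetero atom and one hydrogen-bond acceptor does not shift the number beyond the scatter. Nothing available bears on the reason for this result. The compounds shown leave open whether any group on this carbon can lift the number beyond the scatter. A carboxylic acid or an amine there would address that question.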